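Benzyloxy for 4-fluorobenzyl on an amine nitrogen

The compounds below may be only part of what the source reports. "The series", "measured", "known", "first", "only" and "open" are said of these compounds alone.

In an ADME assay on RAW264.7 cells (Mus musculus) for cytotoxicity, read by trypan blue exclusion, with a stated time of 48 h (a lower number here means a stronger inhibitor of growth, a higher number a weaker inhibitor of growth), compound 2 `Cc1cc(CNCc2ccc(F)cc2)c(C)n1-c1ccc(Cl)cc1` gives 26 ug/mL and stands as the higher of the two numbers available. Compound 3 `Cc1cc(CNCc2ccc(Cl)cc2)c(C)n1-c1ccc(Cl)cc1` gives 0.1 ug/mL as the other number, while compound 1 `Cc1c(CNCc2ccccc2)cc(-c2ccc(Cl)cc2)n1-c1ccc(Cl)cc1` has "not determined" (no result reported) as its entry. Among the compounds with values here, compound 4 `Cc1cc(CNOCc2ccccc2)c(C)n1-c1ccc(Cl)cc1` has no measurement yet and carries benzyloxy in place of 4-fluorobenzyl on an amine nitrogen. Within the data shown here, the one measured step nearby, chloro in place of fluoro on an aromatic carbon, gave a 260-fold lower number from compound 2 to compound 3 (2.41 log units; beyond the scatter) as a large change, yet that step does not involve benzyloxy, so it offers only a loose guide. In this assay a moderate move towards a lower number is expected (a 5.2-fold lower number from compound 2 to compound 4 (0.72 log units; beyond the scatter)) with wide uncertainty. For compound 4 the estimated value is 5 ug/mL with an expected range from 0.4 ug/mL to 40 ug/mL overall.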

Compound 4, concentration for 50% growth inhibition: 133 ug/mL
Compound 4: the middle estimate sits 27-fold (1.42 log units) below what was measured; the whole stated range lies below it.
By their numbers in this assay, from the lowest: compound 3; then compound 2; then compound 4.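

Within this assay benzyloxy in place of 4-fluorobenzyl on an amine nitrogen gave a 5.1-fold higher number from compound 2 to compound 4 (0.71 log units; beyond the scatter) and so showed that a change on this side of the molecule can also raise the number, not only lower it. Benzyloxy in place of 4-chlorobenzyl gave a 1300-fold higher number from compound 3 to compound 4 (3.12 log units; beyond the scatter) and leaves compound 4 with the highest number of the three. Nothing measured here accounts for either step. Still open, going by these compounds, is how a plain benzyl on the shared core or a 4-methoxybenzyl would read, and with them whether the oxygen in the link or the loss of the ring halogen carries the change.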